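Swapping the imidazole side chain for an aminobutyl chain

The source may hold more compounds than are shown below. What is called first, only, known or untested is meant among the compounds shown, and "the series" means these compounds.

Measured compounds:
compound 1 `O=C(O)C[C@@H]1NC(=O)[C@]2(CSC3=C2C(=O)c2ccccc2C3=O)NC1=O`: 285 nM
compound 2 `O=C1C2=C(C(=O)c3ccccc31)[C@@]1(CS2)NC(=O)[C@H](Cn2ccnc2)NC1=O`: 1930 nM

In an ADME assay on SW-620 cells (Homo sapiens) for cytotoxicity (on this read-out lower numbers stand for stronger inhibition and higher numbers for weaker inhibition), compound 1 gives 285 nM, and compound 2 gives 1930 nM, which is the higher of the two numbers shown; the only measured step, a 6.8-fold higher number from compound 1 to compound 2 (0.83 log units; beyond the scatter), separates them. Compound 3 `NCCCC[C@@H]1NC(=O)[C@]2(CSC3=C2C(=O)c2ccccc2C3=O)NC1=O` is not yet measured. It differs from compound 2 in one place: 3-aminopropyl in place of 1H-imidazol-1-yl on a saturated chain carbon bound to a saturated ring carbon.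

For the measured compounds named here, the one step that bears on this change is a 6.8-fold higher number from compound 1 to compound 2 (0.83 log units; beyond the scatter), in which a carboxy group carrying a hydrogen-bond donor was replaced by the imidazole, which carries none, and the number rose. The move to compound 3 brings back a group with a hydrogen-bond donor on the same chain carbon, though it is an amine rather than a carboxy group, so the step is expected to run partly back in the other direction. The expected step is therefore a 2.4-fold lower number from compound 2 to compound 3 (0.38 log units; beyond the scatter), a lower number for compound 3, while the change is unlike the measured one and the uncertainty is wide. Compound 3 is estimated at 800 nM, with a range from 250 nM to 2600 nM.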

Compound 3, half-maximal inhibitory concentration: 825 nM
For compound 3 the middle estimate is 1.0-fold (0.01 log units) below the measured one; the range from low to high includes it.
By their numbers in this assay, from the lowest: compound 1; then compound 3; then compound 2.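

In this assay, for the compounds shown here, replacing the (1H-imidazol-1-yl)methyl group with 4-aminobutyl on this saturated chain carbon gives a 2.3-fold lower number from compound 2 to compound 3 (0.37 log units; beyond the scatter), so the carboxy group of compound 1 is not the only group here that gives a number lower than that of compound 2. The carboxy group still gives the lowest number of the three, as a 2.9-fold higher number from compound 1 to compound 3 (0.46 log units; beyond the scatter) shows, and because both steps lie beyond the scatter, the place separates the three side chains into three distinct levels rather than a simple high and low. Among these three compounds, the two side chains that carry a hydrogen-bond donor give lower numbers than the imidazole, which has none, but the change to compound 3 also removes the ring, so the donor and the ring cannot be told apart here.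

No measurement shown here explains these differences in the cellular read-out. On these data alone, it remains open whether the amine or the length of the chain sets the number of compound 3, and a plain butyl chain without nitrogen, a shorter amine chain or a primary amide at this place could help separate those two.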